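Antiproliferative series: aryl replacement on compound 1

The source may hold more compounds than are shown below. What is called first, only, known or untested is meant among the compounds shown, and "the series" means these compounds.

Measured so far:
- compound 1, `O=C(COc1ccc(C(=O)/C=C/c2ccc(Cl)cc2Cl)cc1)N[C@H]1CCOC1=O`: 8610 nM
- compound 2, `O=C1OCC[C@@H]1NC(=S)SCCOc1ccccc1`: 63800 nM
- compound 3, `Cc1cc(Cl)ccc1NCC(=O)N[C@H]1CCOC1=O`: > 64000 nM (a limit of the assay, not a number)

In a functional assay on DU-145 cells (Homo sapiens) for antiproliferative activity, read by MTT assay, with a stated time of 72 h (on this read-out lower numbers stand for stronger inhibition and higher numbers for weaker inhibition), compound 1 gives 8610 nM, the lowest of the two numbers shown. Compound 2 gives 63800 nM, a number higher than that of compound 1 by more than the scatter. For compound 3 the assay reports only a limit, (the limit of > 64000 nM in this assay, at which 1 of the 3 values shown sits), so no number is known for it.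

Compound 4 is `O=C(COc1ccc(C(=O)/C=C/c2cccc(F)c2)cc1)N[C@H]1CCOC1=O`. It differs from compound 1 in one place: 3-fluorophenyl in place of 2,4-dichlorophenyl on a double-bonded chain carbon bound to a double-bonded chain carbon. Among the compounds with values here, no pair of measured compounds isolates this change, so its size in this assay is not known from the data. The step from compound 1 to compound 4 is expected to be small, a 1.5-fold higher number from compound 1 to compound 4 (0.18 log units; within the scatter), with a lean toward a somewhat higher number for compound 4. Compound 4 is therefore estimated at 13000 nM, with a likely range from 5000 nM to 35000 nM.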

Compound 4, half-maximal inhibitory concentration: 17200 nM
Estimate against measurement, compound 4: 1.3-fold (0.12 log units) below; the range from low to high includes it.
By their numbers in this assay, from the lowest: compounds 1 and 4 (each within the scatter of the next); then compound 2. At a limit, above all of these: compound 3.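

In this assay, 3-fluorophenyl in place of 2,4-dichlorophenyl on a double-bonded chain carbon bound to a double-bonded chain carbon gives a 2.0-fold higher number from compound 1 to compound 4 (0.30 log units; within the scatter). Within the data shown here, this is the first step read at this place, and it shows that the two chlorines of compound 1 can leave and a single fluorine can enter without a change beyond the scatter. Nothing measured here speaks to the reason for this step.

Open, on these data alone, is whether a phenyl with no halogen, or an aryl group carrying an amine or a carboxylic acid, would keep compound 4's reading at this place. This single step changes the kind of halogen, the number of halogens and their ring positions together, so the part played by each cannot be separated.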